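Turning One Ring Stereocentre in a Small Agonist Set

A few compounds are considered here, and "the series" means these few. Any claim that something is new, unique, unknown or untested is made for them only; others in the source may bear on it.

Among the compounds with values here, compound 1, with the structure `CCCCCCCCCCCOc1ccccc1CCC(=O)OC[C@H]1OCCC[C@H]1OP(=O)(O)OC[C@H](N)C(=O)O`, is the only member of this set to return a number in an assay on HEK293-A cells for agonist activity at probable G-protein coupled receptor 34 (Mus musculus), with a stated time of 1.5 h; on this read-out lower numbers stand for smaller maximal responses and higher numbers for larger maximal responses; there compound 1 reaches 5.2%. Compound 2, `N[C@@H](COP(=O)(O)OC[C@H]1OCCC[C@@H]1OC(=O)CCc1ccccc1OCc1cccc(Oc2ccccc2)c1)C(=O)O`, is reported as "not active" (no number reported) in this assay. Compound 3, `CCCCCCCC/C=C\CCCCCCCC(=O)O[C@H]1C=CCO[C@@H]1COP(=O)(O)OC[C@H](N)C(=O)O`, is likewise reported as "not active" (no number reported) in this assay. Against this background stands compound 4, `CCCCCCCCCCCOc1ccccc1CCC(=O)OC[C@H]1OCCC[C@@H]1OP(=O)(O)OC[C@H](N)C(=O)O`. Compared with compound 1, (the two compounds have the same atoms and bonds; at least one stereo element is drawn with a configuration in one of them and without one in the other: 1 of 4 stereo elements differ; a stereocentre at a saturated ring carbon is drawn R in compound 1 and S in compound 4). Within the data shown here, no measured pair in the set shares this kind of change, so no step can be drawn from the data. Because compound 1 gives only 5.2%, the step is expected to stay small, as a number 0.8 percentage points higher from compound 1 to compound 4 (within the scatter), and within the usual scatter. Compound 4 is therefore estimated to reach 6% in this assay, within a range from 0% to 20%.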

Compound 4, largest response reached (Emax), in percent of the reference or control that the assay uses: 5.3%
Estimate against measurement, compound 4: 0.7 percentage points above; the range from low to high includes it.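

The change at the stereocentre on the saturated ring carbon, drawn R and then S, gives a number 0.1 percentage points higher from compound 1 to compound 4 (within the scatter) in this assay. Within the data shown here, this is the first reading of that stereocentre in the set, and on this read-out it does not separate the two compounds, both of which stay at small maximal responses. One caution applies to this reading: the fact that one of compounds 1 and 4 is drawn with a defined configuration and the other without, at the place where they differ.

The compounds shown leave open whether turning this stereocentre would matter in a compound with a larger maximal response. They also leave open whether it would matter with an amide in place of the ester.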